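This account rests on a few compounds, and the source may have more. Where it says the series, first, only, none or still open, it means among the compounds named here.

Measured compounds in a functional assay on HGC-27 cells (Homo sapiens) for inhibition, read by MTT assay, with a stated time of 72 h; on this read-out higher numbers stand for weaker inhibition and lower numbers for stronger inhibition:

Compound 1 `C[C@@H]1CCN(c2cc(-c3ccccc3)nc3ncnn23)C[C@@H]1N(C)c1ncnc2[nH]ccc12`: > 100000 nM, a limit of the assay rather than a number.
Compound 2 `Cc1cc(N2CC[C@@H](C)[C@@H](N(C)c3ncnc4[nH]ccc34)C2)n2nc(SCCc3ccccc3)nc2n1`: 11800 nM.

Among the compounds with values here, compound 2 holds the only actual number in this assay. Within the data shown here, compound 1 sits at the limit (the limit of > 100000 nM in this assay, at which 1 of the 2 values shown sits), which gives a bound and not a number, so no measured step between the two compounds can be sized, and nothing here shows how changes on the sulfur-linked side chain play out.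

Compound 3 `Cc1cc(N2CC[C@@H](C)[C@@H](N(C)c3ncnc4[nH]ccc34)C2)n2nc(SCc3ccc(C(F)(F)F)cc3)nc2n1` is built from compound 2 by a single change: 4-(trifluoromethyl)phenyl in place of benzyl on a saturated chain carbon bound to a sulfur. Cut one bond further out, the same change reads phenethylsulfanyl to (4-(trifluoromethyl)benzyl)sulfanyl; the remainder of the molecule, including the shared core and the saturated ring with its methyl and methylamino substituents, is untouched.

Among the measured compounds shown here, with no measured step of this kind to lean on, the change is expected to move this assay by no more than the usual scatter, with the direction left open. Compound 3 is therefore estimated at 9000 nM, within a range of 3000 nM to 30000 nM. The expected step is a 1.3-fold lower number from compound 2 to compound 3 (0.12 log units; within the scatter), which is within scatter.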

Compound 3, half-maximal inhibitory concentration: 9540 nM
Estimate against measurement, compound 3: 1.1-fold (0.03 log units) below, and the stated range covers the measured number.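

The pair gives a measured step at this position in this assay: placing 4-(trifluoromethyl)phenyl where benzyl stood on a saturated chain carbon bound to a sulfur gives a 1.2-fold lower number from compound 2 to compound 3 (0.09 log units; within the scatter), and this lies within the scatter. The side chain can therefore go from phenethylsulfanyl to (4-(trifluoromethyl)benzyl)sulfanyl, with 10 heavy atoms entering where 7 left and fluorine newly present, without the read-out separating compound 2 from compound 3. Nothing measured here explains this result, and one pair sets no rule for the position.

Compound 1 remains a limit and differs from the other two in more than one place, so steps to it cannot be read: the limit of > 100000 nM in this assay, at which 1 of the 3 values shown sits.

Still open, from the compounds shown here alone, is whether an amine, a carboxylic acid or a longer chain on the sulfur-linked side chain would move the number in this assay beyond the scatter.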